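The source may report more compounds than this note shows. Statements on the series, on what has been measured and on what is new or still open speak of the compounds shown alone.

Measured compounds:
Compound 1 `CCCCOP(=O)(O)OC[C@H]1O[C@@H](n2ccc(N)nc2=O)[C@@H](O)[C@@H]1O` gives 7.5 uM in a functional assay on L1210 cells (Mus musculus) for inhibition; on this read-out lower numbers stand for stronger inhibition and higher numbers for weaker inhibition.
Compound 2 `Nc1ccn([C@@H]2O[C@H](COP(=O)(O)OCc3cccc(OCC(O)CO)c3)[C@@H](O)[C@@H]2O)c(=O)n1` gives 1 uM in this assay.

Among these two numbers, compound 1 stands highest: its nearest neighbour is compound 2, whose number is lower by a margin beyond the usual scatter. For the measured compounds named here, the two compounds differ in several places at once, so no single step between them can be read off.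

Compound 3 `Nc1ccn([C@@H]2O[C@H](COP(=O)(O)OCC(O)CO)[C@@H](O)[C@@H]2O)c(=O)n1` has not yet been measured. It is reached from compound 1 by one change: 1,2-dihydroxyethyl in place of propyl on a saturated chain carbon bound to an oxygen on an unsaturated carbon. Going by the values given here, no measured pair shows this exact change, so the expectation rests only on the two numbers above. Compound 2, which also carries a dihydroxypropyl-type group, gives 1 uM, but its other differences from compound 1 leave the direction open. For compound 3 the step from compound 1 is expected to be small, a 1.3-fold higher number from compound 1 to compound 3 (0.12 log units; within the scatter), within or near the scatter. Compound 3 is therefore estimated at 10 uM, with a range from 3 uM to 30 uM.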

Compound 3, concentration for 50% inhibition: 0.65 uM
Beside the measured number, compound 3's estimate is 15-fold (1.19 log units) above it, and the stated range ends above it.
By their numbers in this assay, from the lowest: compounds 3 and 2 (each within the scatter of the next); then compound 1.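

In this assay, the end of this chain turns out to matter a great deal: 1,2-dihydroxyethyl in place of propyl gives a 12-fold lower number from compound 1 to compound 3 (1.06 log units; beyond the scatter), a large step. Compound 1 and compound 2 could not show this, as they differ in several places at once. The same change can also be read as butoxy to 2,3-dihydroxypropoxy, and it brings in 2 hydrogen-bond donors and 2 hydrogen-bond acceptors where propyl has 0 of each, but no other measurement is at hand to explain the step.

It stays open whether both hydroxyl groups are needed, since a chain with a single hydroxyl group is not among the compounds shown. Also open, from the compounds shown here alone, is how an amine or a carboxylic acid at this chain end would compare.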